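Replacing the cyano group of compound 1

The source may hold more compounds than are shown below. What is called first, only, known or untested is meant among the compounds shown, and "the series" means these compounds.

In a physicochemical assay for lipophilicity, using the shake flask method, measured as octanol-water partition, at pH 7.4 (a higher number here means a more lipophilic compound, a lower number a more polar compound), compound 1 (`CCC(CC)CNc1c(C(N)=O)cnc2ccc(C#N)cc12`) gives 3.5, the higher of the two exact numbers, and compound 3 (`C[C@@H](Nc1c(C(N)=O)cnc2ccc(-c3cccnc3)cc12)C1CCOCC1`) gives 2.3. Compound 2 (`NC(=O)c1cnc2ccc(-c3cccnc3)cc2c1NCC1CCCCC1`), with an aromatic ring at the place in question, reads > 4.3, which is a limit of the assay and not a number. Compound 4 (`CCC(CC)CNc1c(C(N)=O)cnc2ccc(-c3ccc(COC)nc3)cc12`) carries 6-(methoxymethyl)pyridin-3-yl in place of cyano on an aromatic carbon. For the measured compounds named here, the only measured step, a number at least 2.00 log units lower from compound 2 to compound 3 (beyond the scatter), is large but concerns the substituent on nitrogen, so it bears on this change only indirectly. With the limit of compound 2 as a guide, a modest upward move is expected, an estimated a number 0.40 log units higher from compound 1 to compound 4 (beyond the scatter). Compound 4 is expected at 3.9, within a range of 3.3 to 4.5.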

Compound 4, distribution coefficient: > 4.3
Compound 4: a limit, no number; the forecaster's own chance of this, stated with the estimate: 15%; at least 0.40 log units between middle value and limit.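

For the compounds shown here, with the substituent on nitrogen held fixed, this is the first measured change at this aromatic carbon, where this assay shows 6-(methoxymethyl)pyridin-3-yl in place of cyano giving a number at least 0.80 log units higher from compound 1 to compound 4 (beyond the scatter). The step therefore shows that this position alone can move the read-out beyond the scatter, whereas the earlier step concerned only the group on nitrogen. Compound 4 gives > 4.3, a limit of the assay and not a number: the limit of > 4.3 in this assay, at which 2 of the 4 values shown sit.

Going by these compounds, how far the true rise extends remains open. So does the effect of an amine or a carboxylic acid in place of the methoxymethyl group.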